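The compounds below may be only part of what the source reports. "The series", "measured", "known", "first", "only" and "open" are said of these compounds alone.

Working notes on the series. The shared core of compound 1 `O=C(N/N=C/c1ccccc1)c1cnccn1` gives, in an ADME assay on J774 cells (Mus musculus) for cytotoxicity, read by MTT assay, with a stated time of 48 h, tested at 50 ug/mL (on this read-out lower numbers stand for a stronger effect and higher numbers for a weaker effect at the one concentration tested), 100%. Compound 2 `O=C(N/N=C/c1ccc(F)cc1)c1cnccn1` gives 78% and compound 3 `O=C(N/N=C/c1ccccc1Br)c1cnccn1` gives 98%. Compound 3 thus sits with compound 1 at the upper end of the three numbers, the gap a number 2 percentage points lower from compound 1 to compound 3 (within the scatter), while compound 2 lies lower, the gap a number 22 percentage points lower from compound 1 to compound 2 (beyond the scatter).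

Compound 4 `N#Cc1ccccc1/C=N/NC(=O)c1cnccn1` arises from compound 3 by cyano in place of bromo on an aromatic carbon. Within the data shown here, the only steps that bear on a change at this ring are the two halogen steps above: a number 2 percentage points lower from compound 1 to compound 3 (within the scatter) was within the scatter and a number 22 percentage points lower from compound 1 to compound 2 (beyond the scatter) was modest. Among the measured compounds shown here, no step with a cyano group is known. The step of a number 8 percentage points lower from compound 3 to compound 4 (within the scatter) is therefore expected to be small, at most a modest fall. For compound 4 the estimate is 90%, between 70% and 100%.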

Compound 4, a percentage reported as activity, at one concentration (the size of the read-out at that concentration, not a potency): 92%
Estimate against measurement, compound 4: 2 percentage points below; the range from low to high includes it.
By their numbers in this assay, from the lowest: compound 2; then compounds 4, 3 and 1 (each within the scatter of the next).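

In this assay, the aromatic carbon ortho to a large group tolerates cyano as well as bromo, with a number 6 percentage points lower from compound 3 to compound 4 (within the scatter) and a number 8 percentage points lower from compound 1 to compound 4 (within the scatter). A second group, this one with a triple bond, therefore leaves the number at this position level with compound 1, which carries hydrogen there, whereas the fluoro of compound 2 stands apart. Nothing measured here gives a reason for this.

From the compounds shown here alone, whether an amine or a carboxylic acid at this position would also stay within the scatter remains open. So does how cyano would read at the place that fluoro holds in compound 2.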